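Phenyl for methyl on a sulfur

This account rests on a few compounds, and the source may have more. Where it says the series, first, only, none or still open, it means among the compounds named here.

Measured in a functional assay on PC-3 cells (Homo sapiens) for antiproliferative activity, read by MTT assay, with a stated time of 24 h (on this read-out lower numbers stand for stronger inhibition and higher numbers for weaker inhibition), so far
- compound 1 `CCn1c(C(=O)N[C@H](C)C(=O)OC)ccc1C(CC)(CC)c1ccc(OCS(=O)(=O)c2ccccc2)c(C)c1` gives > 50000 nM as a limit
- compound 2 `CCn1c(C(=O)N[C@@H](CO)CCO)ccc1C(CC)(CC)c1ccc(OCS(=O)(=O)c2ccccc2)c(C)c1` gives 14100 nM
- compound 3 `CCN(CC)CCNC(=O)c1cc(C(CC)(CC)c2ccc(OCSC)c(C)c2)cn1CC` gives 9540 nM

The value of compound 1 is only a limit. Compound 3 at 9540 nM lies within the usual scatter of compound 2 at 14100 nM in this comparison. Compound 4 `CCN(CC)CCNC(=O)c1cc(C(CC)(CC)c2ccc(OCSc3ccccc3)c(C)c2)cn1CC` keeps compound 3 except for one place: phenyl in place of methyl on a sulfur. Among the measured compounds shown here, no measured step touches this sulfur. For the measured compounds named here, the one available step, an at least 3.5-fold lower number from compound 1 to compound 2 (0.54 log units; beyond the scatter), concerns an amide-type nitrogen instead, so its size does not carry over. The expected result in this assay is a 1.2-fold lower number from compound 3 to compound 4 (0.08 log units; within the scatter), with no step beyond the scatter. For compound 4 the estimate is 8000 nM, with an expected range from 3000 nM to 22000 nM as its bounds.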

Compound 4, half-maximal inhibitory concentration in the PC-3 assay: 2620 nM
Compound 4: middle estimate off by 3.1-fold (0.48 log units), on the high side; the whole stated range lies above it.
By their numbers in the PC-3 assay, from the lowest: compound 4; then compounds 3 and 2 (each within the scatter of the next). At a limit, above all of these: compound 1.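

Among the compounds shown here, in the PC-3 assay, this sulfur turns out to be a place where the group matters: phenylsulfanyl for methylsulfanyl gives a 3.6-fold lower number from compound 3 to compound 4 (0.56 log units; beyond the scatter), the first measured step at this position. For the compounds shown here, the same change also comes with far less dissolved compound in a physicochemical assay for solubility, read by HPLC, at pH 7.4 (a lower number here means a less soluble compound, a higher number a more soluble compound), a cost that the earlier compounds did not show: the measured solubility of compound 3, 198 ug/mL, and of compound 4, 0.6 ug/mL, a 330-fold lower number (2.52 log units; beyond the scatter) In the physicochemical assay compound 3 gives 198 ug/mL, and compound 4 gives 0.6 ug/mL.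

Still open, going by these compounds, is whether a different group on this sulfur, such as a pyridine ring, a cyclohexyl ring or a short chain ending in an amine, would keep the stronger inhibition while losing less solubility.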